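Removing the aromatic group from compound 3 in the cytotoxicity assay

This account rests on a few compounds, and the source may have more. Where it says the series, first, only, none or still open, it means among the compounds named here.

In an ADME assay on MT2 cells (Homo sapiens) for cytotoxicity, read by MTT assay (a lower number here means that less compound is tolerated, a higher number that more compound is tolerated), compound 3 `[O-][n+]1ccc(OCc2ccc(Nc3ncc(Cc4c(F)cccc4F)o3)cc2Cl)cc1` gives 1700 nM, the lowest of the three numbers: compound 1 `Fc1cccc(F)c1Cc1cnc(Nc2ccc(-c3ccncc3)c(Cl)c2)o1` gives 9300 nM and compound 2 `Fc1cccc(F)c1Cc1cnc(Nc2ccc(Oc3cccnc3)c(Cl)c2)o1` gives 16000 nM, with a 5.5-fold lower number from compound 1 to compound 3 (0.74 log units; beyond the scatter) and a 9.4-fold lower number from compound 2 to compound 3 (0.97 log units; beyond the scatter). Compound 4 `OCc1ccc(Nc2ncc(Cc3c(F)cccc3F)o2)cc1Cl` differs from compound 3 by a hydrogen atom in place of a group of 7 heavy atoms (5 carbon, 1 nitrogen, 1 oxygen; one six-membered aromatic ring with 1 hetero atom), on an oxygen on a saturated carbon. The two steps into compound 3 bear on this change, as each introduced a group holding one six-membered aromatic ring with 1 hetero atom onto the shared core and lowered the number modestly; compound 4 removes such a group from the oxygen on a saturated carbon. A modest rise is therefore expected, a 4.7-fold higher number from compound 3 to compound 4 (0.67 log units; beyond the scatter), back toward the values of compound 1 and compound 2. Compound 4 is estimated at 8000 nM, in a range from 3000 nM to 25000 nM.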

Compound 4, half-maximal cytotoxic concentration: 90000 nM
Compound 4: the middle estimate sits 11-fold (1.05 log units) below what was measured; the measured number lies above the stated range.
By their numbers in this assay, from the lowest: compound 3; then compounds 1 and 2 (each within the scatter of the next); then compound 4.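

In this assay, the hydrogen on the oxygen on a saturated carbon gives a 53-fold higher number from compound 3 to compound 4 (1.72 log units; beyond the scatter) and thus the largest step in this set. The earlier compounds shown here only exchanged one group holding a six-membered aromatic ring with 1 hetero atom for another, whereas hydroxymethyl, which has no such ring, also stands clear of both other compounds, with a 5.6-fold higher number from compound 2 to compound 4 (0.75 log units; beyond the scatter) and with a 9.7-fold higher number from compound 1 to compound 4 (0.99 log units; beyond the scatter) as well. As far as these compounds go, whether a methyl ether on that oxygen, or an amine or a carboxylic acid in place of hydroxymethyl, would keep this higher number remains open. No evidence at hand accounts for the rise.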